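Branched alkyl in place of methoxyethyl at the amino nitrogen

The compounds below may be only part of what the source reports. "The series", "measured", "known", "first", "only" and "open" are said of these compounds alone.

Three compounds sharing one core were tested in an in vitro assay on 293-EBNA cells for binding affinity to corticotropin-releasing factor receptor 1 (Homo sapiens); on this read-out higher numbers stand for weaker inhibition and lower numbers for stronger inhibition. Compound 1 `CCC(COC)N(C)c1nc(C)nc2c1nnn2-c1ccc(C(C)C)cc1Br` gives 11.2 nM. Compound 2 `Cc1nc(N2CCCC2)c2nnn(-c3ccc(C(C)C)cc3Br)c2n1` gives 194 nM. Compound 3 `COCCNc1nc(C)nc2c1nnn2-c1ccc(C(C)C)cc1Br` gives 242 nM, the highest number of the three; it sits close to compound 2, the two values lying within the usual scatter, and far from compound 1. The only differences among these compounds lie in the group on the amino nitrogen, and that group matters: a 22-fold higher number from compound 1 to compound 3 (1.33 log units; beyond the scatter) and a 17-fold higher number from compound 1 to compound 2 (1.24 log units; beyond the scatter), whereas a 1.2-fold higher number from compound 2 to compound 3 (0.10 log units; within the scatter).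

Compound 4 `CCCCC(CCCC)Nc1nc(C)nc2c1nnn2-c1ccc(C(C)C)cc1Br` carries 1-butylpentyl in place of 2-methoxyethyl on a nitrogen on an aromatic ring. The measured steps show that a compact group on this nitrogen, as in compound 2 and compound 3, goes with a weak number, while the larger, branched group of compound 1 goes with a much stronger one, as a 22-fold higher number from compound 1 to compound 3 (1.33 log units; beyond the scatter) shows. Compound 4 brings a larger, branched group again, so a drop in this assay is expected, of about a 13-fold lower number from compound 3 to compound 4 (1.13 log units; beyond the scatter). Compound 4 is therefore estimated at 18 nM, within a range of 5 nM to 70 nM.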

Compound 4, inhibition constant: 4.5 nM
Compound 4: middle estimate off by 4.0-fold (0.60 log units), on the high side; measured number outside the range, below it.
By their numbers in this assay, from the lowest: compound 4; then compound 1; then compounds 2 and 3 (each within the scatter of the next).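

In this assay the change from 2-methoxyethyl to 1-butylpentyl gives a 54-fold lower number from compound 3 to compound 4 (1.73 log units; beyond the scatter) and the change from the pyrrolidin-1-yl group gives a 43-fold lower number from compound 2 to compound 4 (1.63 log units; beyond the scatter) on the same core, so a low number at this nitrogen does not depend on the ether oxygen or the extra methyl group of compound 1. The all-carbon chain, with no hydrogen-bond acceptor, goes further still, with a 2.5-fold lower number from compound 1 to compound 4 (0.40 log units; beyond the scatter) making compound 4 the strongest of the four, though this last step is modest beside the other two. Nothing shown here gives the reason for this result.

Branching and overall chain size rise together in these compounds, so their separate contributions remain open. A straight nonyl chain and the shorter 1-ethylpropyl group would help pull them apart.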